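The compounds below may be only part of what the source reports. "The series", "measured", "known", "first", "only" and "open" are said of these compounds alone.

Working notes on the series. Going by the values given here, in a functional assay on K562 cells (Homo sapiens) for antiproliferative activity, with a stated time of 72 h (a higher number here means a weaker inhibitor, a lower number a stronger inhibitor), compound 2 `OC[C@H]1O[C@@H](n2cnc3c(NCc4cccc(O)c4O)ncnc32)[C@H](O)[C@@H]1O` gives 25800 nM; this is the only value in the set reported as an actual number. Compound 1 `COc1cc(CNc2ncnc3c2ncn3[C@@H]2O[C@H](CO)[C@@H](O)[C@H]2O)cc(OC)c1` is reported in this assay only as a limit, > 166000 nM, sitting at the limit of > 166000 nM in this assay, at which 1 of the 2 values shown sits. Among the compounds with values here, the single measured step, an at least 6.4-fold lower number from compound 1 to compound 2 (0.80 log units; beyond the scatter), is thus read against that limit and gives only a lower bound on its true size.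

Compound 3 `OC[C@H]1O[C@@H](n2cnc3c(NCc4ccc(C(F)(F)F)cc4)ncnc32)[C@H](O)[C@@H]1O` is not yet measured in this assay. It differs from compound 2 by 4-(trifluoromethyl)phenyl in place of 2,3-dihydroxyphenyl on a saturated chain carbon bound to a nitrogen on an aromatic ring. The change runs in the opposite sense to the measured step: both hydroxyl groups of the 2,3-dihydroxyphenyl leave, and a 4-(trifluoromethyl)phenyl with no hydrogen-bond donors or acceptors enters. Compound 1, which likewise carries no donors on that ring, sits at the limit in this assay. Compound 3 is therefore expected to move back toward weaker inhibition, by a step of roughly a 3.5-fold higher number from compound 2 to compound 3 (0.54 log units; beyond the scatter). The estimate for compound 3 in this assay is 90000 nM, within 20000 nM to 300000 nM, with a real chance that only a limit is returned.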

Compound 3, half-maximal inhibitory concentration: > 166000 nM
Compound 3 was reported as a limit (the forecaster's own chance of this, stated with the estimate: 50%); at least 1.8-fold (0.26 log units) between middle value and limit.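

In this assay compound 3 gives > 166000 nM, which is a limit and not a number. Putting 4-(trifluoromethyl)phenyl in place of 2,3-dihydroxyphenyl on a saturated chain carbon bound to a nitrogen on an aromatic ring gives an at least 6.4-fold higher number from compound 2 to compound 3 (0.80 log units; beyond the scatter), a lower bound read against that limit, so the gain seen with 2,3-dihydroxyphenyl now holds against a second ring without hydroxyl groups, and of the three rings only 2,3-dihydroxyphenyl returns an actual number. The step between compound 1 and compound 3 cannot be read, and the two can be placed in no order, as both are limits: the limit of > 166000 nM in this assay, at which 2 of the 3 values shown sit.

Still open, on these data alone, is which of the two hydroxyl groups of compound 2 carries the difference, and whether a ring with a single hydroxyl group, a 2,3-dimethoxyphenyl, or a phenyl bearing an amine or a carboxylic acid would keep a measurable value. Also open, as far as these compounds go, is whether any change at this place improves on compound 2, which gives 25800 nM in this assay.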